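The source may hold more compounds than are shown below. What is called first, only, known or untested is meant among the compounds shown, and "the series" means these compounds.

Compound 3, with the structure `COC(=O)N[C@H](C(=O)N1CCC[C@H]1C(=O)Nc1ccc([C@@H]2CC[C@@H](c3ccc(NC(=O)[C@@H]4CCCN4C(=O)[C@@H](NC(=O)OC)C(C)C)cc3)N2c2ccc(C(F)(F)F)cc2)cc1)C(C)C`, is a large, near-symmetric molecule whose central saturated ring carries a 4-(trifluoromethyl)phenyl group. In a physicochemical assay for lipophilicity, read by HPLC, at pH 7.4 (a lower number here means a more polar compound, a higher number a more lipophilic compound), compound 3 gives 4.8, the second highest of the three numbers in hand. Its nearest neighbour is compound 2, drawn as `COC(=O)N[C@H](C(=O)N1CCC[C@H]1C(=O)Nc1ccc([C@H]2CC[C@H](c3ccc(NC(=O)[C@@H]4CCCN4C(=O)[C@@H](NC(=O)OC)C(C)C)cc3)N2c2ccc(C(F)(F)F)cc2)cc1)C(C)C`, which in this assay gives 4.9; the step of a number 0.10 log units lower from compound 2 to compound 3 (within the scatter) lies within the scatter, as one might expect from the fact that compounds 2 and 3 differ only in the configuration as drawn. The furthest is compound 1, `COC(=O)N[C@H](C(=O)N1CCC[C@H]1C(=O)Nc1ccc([C@@H]2CC[C@@H](c3ccc(NC(=O)[C@@H]4CCCN4C(=O)[C@@H](NC(=O)OC)[C@@H](C)OC)cc3)N2c2ccc(F)cc2)cc1)[C@@H](C)OC`, which gives 3; it differs from compound 3 in more than one place, so its gap cannot be assigned to any single change.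

The next compound, compound 4, is `COC(=O)N[C@H](C(=O)N1CCC[C@H]1C(=O)Nc1ccc([C@@H]2CC[C@@H](c3ccc(NC(=O)[C@@H]4CCCN4C(=O)[C@@H](NC(=O)OC)C(C)C)cc3)N2c2ccc(F)cc2)cc1)C(C)C`. The change from compound 3 is fluoro in place of trifluoromethyl on an aromatic carbon. Going by the values given here, no measured step alters this group on its own, so there is no direct precedent for the size of the step. Compound 1 does carry the 4-fluorophenyl group and sits lowest, but it also carries different side chains, so its value gives only a loose hint of direction.

Taking that hint, the step from compound 3 to compound 4 is expected to be downward, a number 0.80 log units lower from compound 3 to compound 4 (beyond the scatter). Compound 4 is therefore estimated at 4, with a likely range from 3.4 to 4.6.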

Compound 4, distribution coefficient: 4.6
Beside the measured number, compound 4's estimate is 0.60 log units below it, and the stated range covers the measured number.
By their numbers in this assay, from the lowest: compound 1; then compounds 4, 3 and 2 (each within the scatter of the next).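

Going by these compounds alone, this is the first step that alters only this place, an aromatic carbon para to a large group: with fluoro in place of trifluoromethyl, the step is a number 0.20 log units lower from compound 3 to compound 4 (within the scatter) in this assay and stays too small to separate the two compounds. The group shrinks from 4 heavy atoms to 1 while the rest of the molecule is held fixed, and yet the two readings cannot be told apart, so at this place and with these side chains the swap leaves no measurable mark. Nothing in hand bears on why the step is this small.

Going by these compounds, a single step on a single pair sets no pattern, and it remains open whether the same swap would stay as small with the side chains of compound 1 or in the drawn configuration of compound 2. On these data alone, it is also open how the reading would respond at this same place to a group of another kind, such as an amine, a carboxylic acid or a nitrile.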